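Shortening the ester aryl group: ethyl to methyl

A few compounds are considered here, and "the series" means these few. Any claim that something is new, unique, unknown or untested is made for them only; others in the source may bear on it.

Three esters share one core and differ only in the aromatic group on the carbonyl carbon. In an assay on NIH3T3 cells with Urotensin-2 receptor (Homo sapiens) as the target (a lower number here means that less compound is needed, a higher number that more compound is needed for the effect), compound 3 `CCc1ccccc1C(=O)OC(CCN(C)C)c1ccc(Cl)cc1` gives 1290 nM, the second highest of the three numbers. Compound 1 `Cc1ccsc1C(=O)OC(CCN(C)C)c1ccc(Cl)cc1` gives 2510 nM, and the step of a 1.9-fold lower number from compound 1 to compound 3 (0.29 log units; within the scatter) stays within the scatter. Compound 2 `CN(C)CCC(OC(=O)c1ccc(-c2ccccc2)cc1)c1ccc(Cl)cc1` gives 525 nM, a lower number than compound 3 by a gap beyond the scatter. Compound 4 `Cc1ccc(C(=O)OC(CCN(C)C)c2ccc(Cl)cc2)cc1` carries 4-methylphenyl in place of 2-ethylphenyl on a carbonyl carbon. Going by the values given here, no measured step matches this change, and the only step in the set, from compound 1 to compound 3, is too small to count. The step of a 1.4-fold lower number from compound 3 to compound 4 (0.16 log units; within the scatter) is therefore expected to be modest and uncertain, and compound 4 is estimated at 900 nM, within 300 nM to 2700 nM.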

Compound 4, half-maximal effective concentration: 2750 nM
The estimate for compound 4 lay 3.1-fold (0.49 log units) below the measured number; the measured number lies above the stated range.
By their numbers in this assay, from the lowest: compound 2; then compounds 3, 1 and 4 (each within the scatter of the next, the first and the last beyond it).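

In this assay, a 2.1-fold higher number from compound 3 to compound 4 (0.33 log units; beyond the scatter) shows that swapping one small alkyl-substituted phenyl for another on the carbonyl carbon can move the number beyond the scatter. The step of a 5.2-fold higher number from compound 2 to compound 4 (0.72 log units; beyond the scatter) ties the lower number of compound 2 to its phenyl, with methyl in its place. The step of a 1.1-fold higher number from compound 1 to compound 4 (0.04 log units; within the scatter) stays within the scatter, so 4-methylphenyl and 3-methylthiophen-2-yl cannot be told apart here. Nothing measured here explains these steps. Going by these compounds, whether an amine or a carboxylic acid in place of that methyl would give a lower or higher number remains open.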